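A few compounds are considered here, and "the series" means these few. Any claim that something is new, unique, unknown or untested is made for them only; others in the source may bear on it.

Measured so far in a functional assay on CHO cells for positive allosteric modulation of muscarinic acetylcholine receptor M5 (Homo sapiens), read by FLIPR and calcium flux, with a stated time of 1 h; on this read-out lower numbers stand for an effect already at smaller amounts and higher numbers for an effect only at larger amounts of compound:
compound 1 `O=C1C(=O)N(Cc2ccc(-c3ccccc3)nc2)c2ccc(OC(F)(F)F)cc21`: 3800 nM
compound 2 `COc1cccc(Oc2ccc(CN3C(=O)C(=O)c4cc(OC(F)(F)F)ccc43)cc2)n1`: 2200 nM
compound 3 `O=C1C(=O)N(Cc2ccc(-c3ccccc3)cc2F)c2ccc(OC(F)(F)F)cc21`: 5900 nM

All three numbers lie close together in the same range. Compound 1 sits in the middle of the three; compound 3 is its nearest neighbour and compound 2 the furthest, yet both gaps fall within the scatter of repeated measurements, so no order among the three can be read from these values. Among the compounds with values here, no pair among them differs in only one place, so no single-point step has yet been measured.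

The next compound, compound 4 `O=C1C(=O)N(Cc2ccc(-c3cccnc3)nc2)c2ccc(OC(F)(F)F)cc21`, is derived from compound 1 by one change: pyridin-3-yl in place of phenyl on an aromatic carbon. The shared core of compound 1 is kept unchanged.

Within the data shown here, with no measured step of this kind to lean on, the expectation rests on the flat spread of the three numbers. A step in this assay no larger than the scatter is expected, if anything toward a higher number. For compound 4 the estimated step is a 1.3-fold higher number from compound 1 to compound 4 (0.12 log units; within the scatter). Compound 4 is therefore expected to give about 5000 nM in this assay, with a range from 1800 nM to 15000 nM.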

Compound 4, half-maximal effective concentration in the muscarinic acetylcholine receptor M5 assay: 4000 nM
Compound 4: the middle estimate sits 1.3-fold (0.10 log units) above what was measured, and the stated range covers the measured number.
By their numbers in the muscarinic acetylcholine receptor M5 assay, from the lowest: compounds 2, 1, 4 and 3 (each within the scatter of the next, the first and the last beyond it).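

The series now has its first single-point step: pyridin-3-yl in place of phenyl, on an aromatic carbon next to the ring nitrogen, gives in the muscarinic acetylcholine receptor M5 assay a 1.1-fold higher number from compound 1 to compound 4 (0.02 log units; within the scatter). No difference can be read from that step, whereas in a physicochemical assay for lipophilicity (a lower number here means a more polar compound, a higher number a more lipophilic compound), compound 1 gives 3.6 and compound 4 gives 3 and is the more polar of the pair: the measured partition coefficient of compound 1, 3.6, and of compound 4, 3, a number 0.60 log units lower (beyond the scatter) For this pair, then, the position takes a second ring nitrogen, with the hydrogen-bond acceptor counted for pyridin-3-yl, and the partition coefficient moves beyond the scatter while the number in the muscarinic acetylcholine receptor M5 assay does not; this holds for these two compounds only.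

The compounds shown leave open how pyridin-4-yl, morpholine or a carboxylic acid on this same carbon would read in the muscarinic acetylcholine receptor M5 assay, and so how far the position tolerates change beyond one ring nitrogen. Also open, on these data alone, is whether pyridin-3-yl in place of phenyl gives a like result in compound 3, which carries the same phenyl on a different ring.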